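A few compounds are considered here, and "the series" means these few. Any claim that something is new, unique, unknown or untested is made for them only; others in the source may bear on it.

In a functional assay on U-373MG ATCC cells (Homo sapiens) for inhibition, read by colorimetric assay and MTT assay, with a stated time of 72 h (a higher number here means a weaker inhibitor, a lower number a stronger inhibitor), compound 1 `C=CCCCCOc1ccccc1-c1cnc(OCCC=C)n1C` gives 33000 nM. Compound 2 `C=CCCCCOc1ccc(C)cc1-c1cnc(OCCC=C)n1C` gives 33000 nM, level with compound 1, and together they hold the highest number of the three measured. Compound 3 `C=CCCOc1ncc(-c2ccccc2OC)n1C` gives 16000 nM, the furthest from compound 1.

Compound 4 `C=CCCCCOc1ccccc1-c1cnc(OC)n1C` keeps the core of compound 1 but cuts back one of its chains, so that but-3-en-1-yl becomes methyl, or (but-3-en-1-yl)oxy becomes methoxy. The change is hydrogen in place of allyl on a saturated chain carbon bound to an oxygen on an aromatic ring, with hydrogen in place of allyl on a saturated chain carbon bound to an oxygen on an aromatic ring.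

The closest measured precedent is hydrogen in place of pent-4-en-1-yl, described by the same place words but on the other chain, which gave a 2.1-fold lower number from compound 1 to compound 3 (0.31 log units; beyond the scatter). The other measured step, no change at the digits printed from compound 1 to compound 2 (within the scatter), concerns an aromatic carbon and says little about this change. Among the measured compounds shown here, no measured pair shortens this particular chain, so the precedent is only a single, indirect one.

A modest move toward a lower number in this assay is therefore expected, and it may not clear the scatter. The expected step is a 1.7-fold lower number from compound 1 to compound 4 (0.22 log units; within the scatter). Compound 4 is estimated at 20000 nM, with an expected range of 9000 nM to 42000 nM.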

Compound 4, half-maximal inhibitory concentration: > 100000 nM
Compound 4 was reported as a limit (the forecaster's own chance of this, stated with the estimate: 10%); middle value at least 5.0-fold (0.69 log units) away from the limit.
By their numbers in this assay, from the lowest: compound 3; then compounds 1 and 2 (each within the scatter of the next). At a limit, above all of these: compound 4.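

In this assay, cutting (but-3-en-1-yl)oxy back to methoxy gives an at least 3.0-fold higher number from compound 1 to compound 4 (0.48 log units; beyond the scatter), whereas the only earlier chain cut, which removed pent-4-en-1-yl from the other chain, gave a 2.1-fold lower number from compound 1 to compound 3 (0.31 log units; beyond the scatter). These two steps run in opposite directions, so the two chains do not respond alike to being cut back, even though both changes are described as occurring on a saturated chain carbon bound to an oxygen on an aromatic ring, and the earlier step cannot be carried over to this position. The value for compound 4 is a limit and not a number: the limit of > 100000 nM in this assay, at which 1 of the 4 values shown sits.

The compounds shown do not separate the length of this chain from its double bond, and a saturated butoxy chain or a shorter ethoxy chain in place of the (but-3-en-1-yl)oxy would be needed to tell these apart. As far as these compounds go, it also remains open how an amine-bearing chain would behave here, and whether the same cut would have the same outcome on compound 2, which carries the additional methyl on an aromatic carbon.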